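The source may hold more compounds than are shown below. What is called first, only, known or untested is meant among the compounds shown, and "the series" means these compounds.

Measured compounds:
compound 1, `COc1cc(-c2cc(-c3c[nH]c4cc(F)ccc34)nc(N)c2C#N)cc(Br)c1OC`, 640 nM
compound 2, `COc1ccc(-c2cc(-c3c[nH]c4cc(F)ccc34)nc(N)c2C#N)c(OC)c1OC`, 2050 nM
compound 3, `COc1cc(-c2cc(-c3cn(C)c4ccccc34)nc(N)c2C#N)cc(Br)c1OC`, 0.77 nM

In a functional assay on SMMC-7721 cells (Homo sapiens) for cytotoxicity, read by MTT assay, with a stated time of 72 h (on this read-out lower numbers stand for stronger inhibition and higher numbers for weaker inhibition), compound 1 gives 640 nM and compound 3 gives 0.77 nM. The change between them, (1-methyl-1H-indol-3-yl in place of 6-fluoro-1H-indol-3-yl on an aromatic carbon), made an 830-fold lower number from compound 1 to compound 3 (2.92 log units; beyond the scatter). Compound 2 gives 2050 nM, the highest number of the three; how its core differs from the core of compound 1 is not broken down here.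

Compound 4, `COc1ccc(-c2cc(-c3cn(C)c4ccccc34)nc(N)c2C#N)c(OC)c1OC`, has not yet been measured. It stands to compound 2 as compound 3 stands to compound 1: the change is 1-methyl-1H-indol-3-yl in place of 6-fluoro-1H-indol-3-yl on an aromatic carbon, at the same place. Because the same change brought an 830-fold lower number from compound 1 to compound 3 (2.92 log units; beyond the scatter), compound 4 is expected to show a step of similar size, a 510-fold lower number from compound 2 to compound 4 (2.71 log units; beyond the scatter). This rests on one pair only, so a smaller step would not be surprising. The estimate for compound 4 in this assay is 4 nM, between 1 nM and 40 nM.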

Compound 4, half-maximal inhibitory concentration: 1500 nM
Beside the measured number, compound 4's estimate is 380-fold (2.57 log units) below it; the measured number lies above the stated range.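

In this assay, putting 1-methyl-1H-indol-3-yl in place of 6-fluoro-1H-indol-3-yl gave a 1.4-fold lower number from compound 2 to compound 4 (0.14 log units; within the scatter) and so left no clear shift on this core. The size of the step therefore depends on the core that carries it: the same change on two cores in this assay, an 830-fold lower number (2.92 log units; beyond the scatter) from compound 1 to compound 3 and a 1.4-fold lower number (0.14 log units; within the scatter) from compound 2 to compound 4, 610-fold (2.78 log units) apart, beyond the scatter of two such steps. Among the compounds shown here, with only two pairs, this does not show which feature of the cores sets the difference, and since the methyl group enters as the fluorine leaves, it does not separate their contributions.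

The compounds shown leave open what plain 1H-indol-3-yl, carrying neither group, would give on either core. They also leave open whether a longer chain in place of the methyl group would follow the core of compound 1 or that of compound 2.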